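The source may report more compounds than this note shows. Statements on the series, on what has been measured and on what is new or still open speak of the compounds shown alone.

Measured so far in a functional assay on KYSE-450 cells (Homo sapiens) for inhibition, read by MTT assay, with a stated time of 48 h; a lower number here means a stronger inhibitor, a higher number a weaker inhibitor:
compound 1 `C/C=C/C(=O)N(Cc1ccc(OC)c([N+](=O)[O-])c1)c1cc(OC)c(OC)c(OC)c1`: 510 nM
compound 2 `COc1ccc(CNc2cc(OC)c(OC)c(OC)c2)cc1[N+](=O)[O-]`: 16800 nM
compound 3 `COc1ccc(CNc2cc(OC)c(OC)c(OC)c2)cc1Br`: 39800 nM

Of these three, compound 3 carries the highest number, at 39800 nM in this assay, so it is the weakest inhibitor of the set. The next compound, compound 4 `C/C=C/C(=O)N(Cc1ccc(OC)c(Br)c1)c1cc(OC)c(OC)c(OC)c1`, has not been measured. It differs from compound 3 by a single change: (prop-1-en-1-yl)carbonyl in place of hydrogen on a nitrogen on an aromatic ring. In words, this is (prop-1-en-1-yl)carbonyl in place of hydrogen on a nitrogen on an aromatic ring.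

Among the measured compounds shown here, two measured steps bear on this change. The first is the same change read backwards, in compounds that carry nitro rather than bromo: a 33-fold higher number from compound 1 to compound 2 (1.52 log units; beyond the scatter). Losing the group raised the number by a large step, so adding it should lower the number by a similar amount. The second step, a 2.4-fold higher number from compound 2 to compound 3 (0.37 log units; beyond the scatter), is modest and shows the bromo compound sitting somewhat higher than its nitro counterpart. For the measured compounds named here, no pair of bromo compounds has yet tested whether the large step carries over, and that uncertainty widens the range.

A large drop in this assay is therefore expected, and the estimated step is a 33-fold lower number from compound 3 to compound 4 (1.52 log units; beyond the scatter). For compound 4 the expected value is 1200 nM, with an estimated range from 300 nM to 5000 nM.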

Compound 4, half-maximal inhibitory concentration: 10500 nM
Beside the measured number, compound 4's estimate is 8.8-fold (0.94 log units) below it; the whole stated range lies below it.
By their numbers in this assay, from the lowest: compound 1; then compounds 4 and 2 (each within the scatter of the next); then compound 3.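

In this assay, placing the (prop-1-en-1-yl)carbonyl group on the nitrogen still lowers the number when bromo is on the aromatic carbon, but the step is only modest: a 3.8-fold lower number from compound 3 to compound 4 (0.58 log units; beyond the scatter). The size of this step therefore depends on the other group, and it is much larger with nitro than with bromo: the same change on two cores in this assay, a 33-fold higher number (1.52 log units; beyond the scatter) from compound 1 to compound 2 and a 3.8-fold higher number (0.58 log units; beyond the scatter) from compound 4 to compound 3, 8.7-fold (0.94 log units) apart, beyond the scatter of two such steps. Read the other way, bromo in place of nitro gives a large step when the nitrogen carries the (prop-1-en-1-yl)carbonyl group, a 21-fold higher number from compound 1 to compound 4 (1.31 log units; beyond the scatter), but only a modest one when it carries hydrogen, so in these four compounds the two places do not act independently: the same change on two cores in this assay, a 2.4-fold higher number (0.37 log units; beyond the scatter) from compound 2 to compound 3 and a 21-fold higher number (1.31 log units; beyond the scatter) from compound 1 to compound 4, 8.7-fold (0.94 log units) apart, beyond the scatter of two such steps.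

On these data alone, it remains open whether the large step is special to nitro or would also appear with a nitrile or an amine on that aromatic carbon. Also open, as far as these compounds go, is whether the double bond in the group matters, a question that a saturated butanoyl group on the same nitrogen could answer.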